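Opening of a Deoxyribonuclease Inhibitor Series

This account rests on a few compounds, and the source may have more. Where it says the series, first, only, none or still open, it means among the compounds named here.

Measured compounds:
- compound 1 `CC(=O)Nc1ccc2[nH]c(=O)n(O)c(=O)c2c1`: 87000 nM
- compound 2 `O=C(c1nc(-c2cccs2)[nH]c(=O)c1O)N1CCCC1`: "not determined" (no result reported)

Compound 1 was tested in an assay on isolated protein for inhibition of deoxyribonuclease-1 (Homo sapiens) (a higher number here means a weaker inhibitor, a lower number a stronger inhibitor), and gives 87000 nM, which is a weak inhibition. Compound 2 shares no scaffold with compound 1, and for compound 2 the entry in this assay is "not determined" (no result reported), so its standing on the numbers shown is simply unknown.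

Compound 3 `CC(=O)NCCNC(=O)c1nc(-c2cccs2)[nH]c(=O)c1O` differs from compound 2 in one place: (2-acetamidoethyl)amino in place of pyrrolidin-1-yl on a carbonyl carbon. Among the measured compounds shown here, because no step between measured compounds is available, the size and direction of the effect of this change cannot be read from the data; no change beyond the usual scatter is assumed, and the expectation for compound 3 rests only on the weak inhibition of compound 1 as the sole reference point.

For compound 3 in this assay the expected value is 30000 nM, with a range from 3000 nM to 300000 nM.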

Compound 3, half-maximal inhibitory concentration: 62600 nM
Beside the measured number, compound 3's estimate is 2.1-fold (0.32 log units) below it; low and high end bracket the measured number.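

Compound 2 has no number to set against compound 3, so no step can be read for the swap of pyrrolidin-1-yl for (2-acetamidoethyl)amino. The compounds shown leave open what that swap does to inhibition. Nothing further shown bears on the result of compound 3.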